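The source may hold more compounds than are shown below. What is called first, only, known or untested is meant among the compounds shown, and "the series" means these compounds.

Working notes on the amide series. Compound 1 `CC(C)[C@H](C(=O)Nc1ccccc1)c1ccc(Cl)cc1` is the parent amide; in a functional assay on CHO cells for agonist activity at Free fatty acid receptor 2 (Homo sapiens), read by cAMP accumulation (a higher number here means a larger maximal response, a lower number a smaller maximal response), compound 1 reaches a limit of the assay, < 30%. For the measured compounds named here, compound 2 `Cc1csc(NC(=O)[C@H](c2ccc(Cl)cc2)C(C)C)n1` carries a five-membered aromatic ring with 1 nitrogen and 1 sulfur on the amide nitrogen, and in this assay compound 2 gives 87%; the only one-place step measured so far is a number at least 57 percentage points higher from compound 1 to compound 2 (beyond the scatter). Compound 3 `CC(C)(C)[C@H](C(=O)Nc1ncc(F)s1)c1ccc(Cl)cc1` gives 92% in this assay, one of the two numbers in hand and within the scatter of compound 2, so no order between compound 3 and compound 2 is claimed.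

Compound 4 `CN(C)c1cnc(NC(=O)[C@H](c2ccc(Cl)cc2)C(C)(C)C)s1` is not yet measured. It differs from compound 3 by dimethylamino in place of fluoro on an aromatic carbon. Going by the values given here, no measured step touches this place: the step from compound 1 to compound 2 concerns the ring on the amide nitrogen, not a substituent on that ring. Among the compounds with values here, compound 2 and compound 3 differ in two places at once, so their pair shows only that both values are high. The expectation for compound 4 is therefore a step of a number 7 percentage points lower from compound 3 to compound 4 (within the scatter), within the scatter. Compound 4 is estimated at 85%, with a range of 60% to 100%.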

Compound 4, largest response reached (reported as efficacy), in percent of the reference or control that the assay uses: 112%
Estimate against measurement, compound 4: 27 percentage points below, outside the stated range (above it).
By their numbers in this assay, from the lowest: compounds 2 and 3 (each within the scatter of the next); then compound 4. At a limit, below all of these: compound 1.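

In this assay, for the compounds shown here, dimethylamino in place of fluoro on the aromatic carbon next to the ring sulfur gives a number 20 percentage points higher from compound 3 to compound 4 (beyond the scatter), the first measured step at this place, so the maximal response depends on the substituent on this ring as well as on the ring carried by the amide nitrogen. In this one pair, the larger dimethylamino group, which also counts a hydrogen-bond acceptor where fluoro has none, brings no loss of response. Nothing measured for these compounds gives a cause for this step.

From the compounds shown here alone, this single pair does not separate the size of the group from its acceptor, so it remains open how a methoxy group, a morpholine ring or a plain hydrogen at this carbon would compare. Going by these compounds, it also remains open whether the same change gives a similar step on a core with a different alkyl group, such as that of compound 2.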